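Propyl in Place of Bromo: an Expected Dose

A few compounds are considered here, and "the series" means these few. Any claim that something is new, unique, unknown or untested is made for them only; others in the source may bear on it.

Compound 1, `Nc1nc(N)c2nc(CNc3ccc(C(=O)N[C@@H](CC(F)C(=O)O)C(=O)O)cc3F)cnc2n1`, gives 0.62 mg/kg in a functional assay on the whole organism with Rattus norvegicus as the target; a higher number here means that more compound is needed for the effect, a lower number that less compound is needed.
Compound 2, `Nc1nc(N)c2nc(CNc3ccc(C(=O)N[C@@H](CC(F)C(=O)O)C(=O)O)cc3Br)cnc2n1`, gives 0.43 mg/kg in this assay.

These two numbers are all that has been measured. Among the compounds with values here, the single step between them, a 1.4-fold lower number from compound 1 to compound 2 (0.16 log units; within the scatter), swaps one halogen for another and stays within the scatter, so compound 1 and compound 2 stand side by side rather than in any order. Compound 2 therefore sits at one end of a very short range whose only other member, compound 1, cannot be told apart from it.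

Compound 3, `CCCc1cc(C(=O)N[C@@H](CC(F)C(=O)O)C(=O)O)ccc1NCc1cnc2nc(N)nc(N)c2n1`, has not yet been measured. It differs from compound 2 in one place: propyl in place of bromo on an aromatic carbon. Within the data shown here, no measured step replaces a halogen with a carbon chain; the only step available, a 1.4-fold lower number from compound 1 to compound 2 (0.16 log units; within the scatter), shows that a change at this same aromatic carbon left the number essentially unmoved. Among the measured compounds shown here, with no step pointing either way, the expectation for compound 3 is a change no larger than the scatter, written as a 1.2-fold higher number from compound 2 to compound 3 (0.07 log units; within the scatter). The estimated value for compound 3 is 0.5 mg/kg, with a likely range from 0.2 mg/kg to 1.3 mg/kg.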

Compound 3, dose for half-maximal effect: 1.6 mg/kg
Compound 3: the middle estimate sits 3.2-fold (0.51 log units) below what was measured; measured number outside the range, above it.
By their numbers in this assay, from the lowest: compounds 2 and 1 (each within the scatter of the next); then compound 3.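

Replacing bromo with propyl on this aromatic carbon in this assay brings a 3.7-fold higher number from compound 2 to compound 3 (0.57 log units; beyond the scatter) and replacing fluoro with propyl brings a 2.6-fold higher number from compound 1 to compound 3 (0.41 log units; beyond the scatter) with both steps pointing the same way, toward more compound being needed for the effect. The swap between the two halogens stayed within the scatter, so it gave no sign that this carbon could tell one group from another; propyl is the first group shown here to move the number beyond the scatter, though only modestly and on the strength of a single compound. Nothing available explains why the number rises with propyl, so the change stands as an observation and no more.

What the compounds shown leave open is whether the rise belongs to carbon chains in general: a methyl or ethyl group might stay with the halogens, while a butyl chain might need still more compound. From the compounds shown here alone, it is equally open how a group of another kind, such as methoxy, an amine or a nitrile, would fare on this same carbon.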